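The source may report more compounds than this note shows. Statements on the series, on what has been measured and on what is new or still open speak of the compounds shown alone.

In a functional assay on MOLT-4 cells (Homo sapiens) for inhibition, read by MTT assay, with a stated time of 72 h (on this read-out higher numbers stand for weaker inhibition and lower numbers for stronger inhibition), three compounds have been measured so far. Compound 1 (`COc1cc(NC(C)CCCNC(=O)Nc2cccc(F)c2)c2ncccc2c1`) gives 23000 nM, compound 2 (`COc1cc(NC(C)CCCNC(=O)Nc2ccc(Br)cc2)c2ncccc2c1`) gives 25000 nM, and compound 3 (`COc1cc(NC(C)CCCNC(=O)NNC(=O)Nc2ccc(C(F)(F)F)cc2)c2ncccc2c1`) gives 24000 nM. Compound 2 thus stands within the scatter of both other compounds, and the numbers set no order among the three.

Compound 4 (`COc1cc(NC(C)CCCNC(=O)Nc2ccc(F)cc2)c2ncccc2c1`) departs from compound 2 at one place: fluoro in place of bromo on an aromatic carbon. In words, this is fluoro in place of bromo on an aromatic carbon, which turns 4-bromophenyl into 4-fluorophenyl.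

Among the compounds with values here, only one measured step bears on this change: a 1.1-fold higher number from compound 1 to compound 2 (0.04 log units; within the scatter), with 4-bromophenyl in place of 3-fluorophenyl on an amide-type nitrogen. That step lies within the scatter, although it is not the same exchange, since the fluoro there is not para to a large group. No step beyond the scatter is therefore expected in this assay, and no direction is favoured.

The expected change is a 1.0-fold lower number from compound 2 to compound 4 (0.02 log units; within the scatter). For compound 4, the estimated value is 24000 nM, with an expected range from 13000 nM to 42000 nM.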

Compound 4, half-maximal inhibitory concentration: 24000 nM
Estimate against measurement, compound 4: no gap at the digits printed, and the stated range covers the measured number.
By their numbers in this assay, from the lowest: compounds 1, 3, 4 and 2 (each within the scatter of the next).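

With fluoro in place of bromo on an aromatic carbon para to a large group, this assay gives a 1.0-fold lower number from compound 2 to compound 4 (0.02 log units; within the scatter) and so shows that this exchange of one halogen for another, at a single place, does not take the read-out beyond the scatter. Within the data shown here, the earlier compounds could not show this, since their one step changed both the halogen and its place on the ring. The new pair with the halogen kept as fluoro, a 1.0-fold higher number from compound 1 to compound 4 (0.02 log units; within the scatter) for 4-fluorophenyl in place of 3-fluorophenyl, also stays within the scatter.

Going by these compounds, whether an amine or a carboxylic acid at this place would leave the number where it stands remains open. So does the outcome with a longer chain in the part of the molecule that links the core to the aryl group. Nothing available explains why these numbers stay together.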